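A few compounds are considered here, and "the series" means these few. Any claim that something is new, unique, unknown or untested is made for them only; others in the source may bear on it.

Working notes on the ring-amide series. Compound 1 `O=C1NC(C(=O)Nc2ccccc2)CCCCCCC1CS` carries a phenyl on the exocyclic amide nitrogen; in an assay on kidney for inhibition of Neprilysin (Rattus norvegicus) (a higher number here means a weaker inhibitor, a lower number a stronger inhibitor), compound 1 gives 551 nM. Compound 2 `O=C1NC(C(=O)N[C@H](CO)C(=O)O)CCCCCCC1CS` carries 1-carboxy-2-hydroxyethyl in the same place, and in this assay compound 2 gives 11 nM. For the measured compounds named here, the only measured step is a 50-fold lower number from compound 1 to compound 2 (1.70 log units; beyond the scatter), so compound 2 stands as the lowest of the two numbers in hand, with compound 1 the nearest neighbour and well beyond the scatter from it.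

Compound 3 `O=C1NC(C(=O)NCCCO)CCCCCCC1CS` is not yet measured. Its change from compound 2 reads (3-hydroxypropyl in place of 1-carboxy-2-hydroxyethyl on an amide-type nitrogen); the 1-carboxy-2-hydroxyethyl that leaves is the group whose arrival from compound 1 produced the large step to compound 2, and what enters keeps only the hydroxyl end of that group without the carboxy. Going by the values given here, the one step that bears on this is a 50-fold lower number from compound 1 to compound 2 (1.70 log units; beyond the scatter), and its size suggests that the gain of compound 2 over compound 1 is tied to the group now removed. A higher number in this assay is therefore expected for compound 3, though the anilide of compound 1 is not the same replacement, so the size is uncertain. The expected step is a 27-fold higher number from compound 2 to compound 3 (1.44 log units; beyond the scatter). Compound 3 is estimated at 300 nM, within a range of 60 nM to 1500 nM.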

Compound 3, half-maximal inhibitory concentration: 209 nM
Estimate against measurement, compound 3: 1.4-fold (0.16 log units) above; the range from low to high includes it.
By their numbers in this assay, from the lowest: compound 2; then compound 3; then compound 1.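

The change to 3-hydroxypropyl gives a 19-fold higher number from compound 2 to compound 3 (1.28 log units; beyond the scatter) in this assay, so the hydroxyl retained in the new group does not by itself hold the low number of compound 2 at this amide-type nitrogen. Against the phenyl of the anilide, the same group gives only a 2.6-fold lower number from compound 1 to compound 3 (0.42 log units; beyond the scatter), which shows that this position does respond to a change from phenyl to an open hydroxyalkyl chain, but that such a chain recovers only a small part of a 50-fold lower number from compound 1 to compound 2 (1.70 log units; beyond the scatter). No independent measurement accompanies these numbers to account for either step.

The 1-carboxy-2-hydroxyethyl group differs from 3-hydroxypropyl in its carboxylic acid, the placement of its hydroxyl and its defined stereocentre, and the compounds shown do not separate these features, so it remains open which of them carries the large step. A simple carboxymethyl group, holding the carboxylic acid without the hydroxyl, would bear on that question, while a terminal amine or a longer chain in place of the 3-hydroxypropyl would show how far the chain end alone can move the number.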